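A few compounds are considered here, and "the series" means these few. Any claim that something is new, unique, unknown or untested is made for them only; others in the source may bear on it.

Working notes on the series.

Among the compounds with values here, compound 1 `CN1CCN(CCCS(=O)(=O)c2ccc3nc(NC(=O)NC(=O)c4cc(-n5cccn5)ccc4Cl)sc3c2)CC1` gives 2 in a physicochemical assay for lipophilicity (on this read-out higher numbers stand for higher lipophilicity and lower numbers for lower lipophilicity), the lowest of the three numbers measured so far. Its nearest neighbour is compound 3 `CN1CCN(CCCS(=O)(=O)c2ccc3nc(NC(=O)NC(=O)c4cc(-n5cccn5)c(Cl)cc4Cl)sc3c2)CC1`, which gives 2.3 in this assay; the step is a number 0.30 log units higher from compound 1 to compound 3 (within the scatter). Furthest is compound 2 `CN1CCC(S(=O)(=O)c2ccc3nc(NC(=O)NC(=O)c4cc(-n5cccn5)ccc4Cl)sc3c2)CC1`, which gives 2.5 in this assay; here the step is a number 0.50 log units higher from compound 1 to compound 2 (beyond the scatter).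

Compound 4 `Cc1ccn(-c2ccc(Cl)c(C(=O)NC(=O)Nc3nc4ccc(S(=O)(=O)CCCN5CCN(C)CC5)cc4s3)c2)n1` has not yet been measured. Compared with compound 1 the difference is methyl in place of hydrogen on an aromatic carbon. Neither measured step is the same change. The step to compound 2 exchanges the whole group on the sulfonyl sulfur and does not bear on a single small substituent entering a ring carbon. The step to compound 3 is the closer precedent, a single small group entering on an aromatic carbon, and it stayed within the scatter. On that basis a small upward step is expected from compound 1 to compound 4, and it may not exceed the scatter: a number 0.30 log units higher from compound 1 to compound 4 (within the scatter). For compound 4 the estimate in this assay is 2.3, with a range from 1.9 to 2.7.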

Compound 4, distribution coefficient: 2.6
Compound 4: the middle estimate sits 0.30 log units below what was measured; the range from low to high includes it.
By their numbers in this assay, from the lowest: compounds 1, 3, 2 and 4 (each within the scatter of the next, the first and the last beyond it).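

In this assay, methyl in place of hydrogen on an aromatic carbon of the five-membered aromatic ring with 2 nitrogen, the change from 1H-pyrazol-1-yl to 3-methyl-1H-pyrazol-1-yl, gives a number 0.60 log units higher from compound 1 to compound 4 (beyond the scatter) as the first step read at this position. With only 1 heavy atom entering, it lies beyond the scatter, as does the exchange of the whole group on the sulfonyl sulfur in a number 0.50 log units higher from compound 1 to compound 2 (beyond the scatter) and unlike the entry of chloro on an aromatic carbon elsewhere in the molecule in a number 0.30 log units higher from compound 1 to compound 3 (within the scatter) within the scatter. No measurement shown accounts for the size of the step at this ring.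

The compounds shown leave open whether ethyl, methoxy or an amine on this same carbon would give a step of similar size, and whether methyl on another carbon of the ring would match it. They also leave open whether 3-methyl-1H-pyrazol-1-yl would give a comparable step on the core of compound 2 or compound 3, where the sulfonyl group or the chloro pattern differs.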